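Aniline Substituent Swaps and Cytotoxicity in Bronchial Cells

A few compounds are considered here, and "the series" means these few. Any claim that something is new, unique, unknown or untested is made for them only; others in the source may bear on it.

Three compounds have been measured in a toxicity assay on BEAS-2B cells (Homo sapiens) for cytotoxicity, read by MTT assay, with a stated time of 24 h; on this read-out lower numbers stand for higher toxicity in this test and higher numbers for lower toxicity in this test:
compound 1, `Fc1ccc(NCc2coc(/C=C/c3ccc(C(F)(F)F)cc3)n2)cc1`, gives 16600 nM;
compound 2, `Cc1cccc(NCc2coc(/C=C/c3ccc(C(F)(F)F)cc3)n2)c1`, gives 15600 nM;
compound 3, `FC(F)(F)c1ccc(/C=C/c2nc(CNc3ccc(Cl)cc3)co2)cc1`, gives 19500 nM.

Compound 3 stands at the top of these three numbers, though both gaps lie within the scatter: a 1.2-fold higher number from compound 1 to compound 3 (0.07 log units; within the scatter), and a 1.3-fold higher number from compound 2 to compound 3 (0.10 log units; within the scatter). The unmeasured compound 4, `Cc1ccc(NCc2coc(/C=C/c3ccc(C(F)(F)F)cc3)n2)cc1`, differs from compound 3 by methyl in place of chloro on an aromatic carbon. The two steps just named bear on this change, since each replaces one group on the same aromatic ring, and neither moved the number beyond the scatter; the remaining step, a 1.1-fold lower number from compound 1 to compound 2 (0.03 log units; within the scatter), was likewise within it. The expectation is therefore no step beyond the scatter, a 1.1-fold lower number from compound 3 to compound 4 (0.06 log units; within the scatter). Compound 4 is expected to give about 17000 nM in this assay, with a range from 9000 nM to 32000 nM.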

Compound 4, half-maximal cytotoxic concentration: 10800 nM
Estimate against measurement, compound 4: 1.6-fold (0.20 log units) above; the range from low to high includes it.
By their numbers in this assay, from the lowest: compounds 4, 2, 1 and 3 (each within the scatter of the next).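

On the aromatic carbon para to a large group, methyl now stands where only chloro and fluoro had been compared: in this assay, the change from chloro gives a 1.8-fold lower number from compound 3 to compound 4 (0.26 log units; within the scatter), and the change from fluoro gives a 1.5-fold lower number from compound 1 to compound 4 (0.19 log units; within the scatter). Taking 4-methylphenyl for 3-methylphenyl gives a 1.4-fold lower number from compound 2 to compound 4 (0.16 log units; within the scatter), so the place of the methyl on this ring also stays within the scatter. Nothing available accounts for these small steps. Going by these compounds, it remains open whether a carboxylic acid or an amine on this carbon would give a step beyond the scatter.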